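The source may report more compounds than this note shows. Statements on the series, on what has been measured and on what is new or still open speak of the compounds shown alone.

Compound 1 `CS(=O)(=O)CCCn1c(Cn2cc(S(C)(=O)=O)c3cc(F)ccc32)nc2cc(Cl)ccc21`: > 100000 nM
Compound 2 `CS(=O)(=O)c1nn(Cc2nc3cc(Cl)ccc3n2CCCCO)c2cnccc12`: > 100000 nM

In an ADME assay on HEp-2 cells (Homo sapiens) for cytotoxicity, with a stated time of 4 days (on this read-out lower numbers stand for higher toxicity in this test and higher numbers for lower toxicity in this test), compound 2 reaches only the limit of the test and gives > 100000 nM. Compound 1 likewise gives no number but a limit, > 100000 nM. Within the data shown here, both values sit at the limit of > 100000 nM in this assay, at which 2 of the 2 values shown sit, so compound 2 stands at the same limit as the only other measured compound, and no measured step exists that would place it higher or lower.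

Compound 3 `CS(=O)(=O)c1nn(Cc2nc3cc(Cl)ccc3n2CCC(O)C(F)F)c2cnccc12` differs from compound 2 by 2,2-difluoro-1-hydroxyethyl in place of 2-hydroxyethyl on a saturated chain carbon, two bonds along the chain from an aromatic nitrogen. Among the measured compounds shown here, because no step between two measured compounds has been recorded, the size of this change in this assay cannot be read from the data; nothing among the measured compounds points to a shift beyond the scatter in either direction. Compound 3 is therefore expected to come out at 100000 nM, within a range of 50000 nM to 300000 nM, and the step of a number no higher from compound 2 to compound 3 (the limit leaves the size open) is estimated to be none beyond the scatter.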

Compound 3, half-maximal cytotoxic concentration: > 100000 nM
Compound 3 was reported as a limit (the forecaster's own chance of this, stated with the estimate: 85%); the middle value sits exactly at the limit.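

Among these compounds, compound 2 and compound 3 are both reported only as limits in this assay and no step between them can be read: the limit of > 100000 nM in this assay, at which 3 of the 3 values shown sit.

The compounds shown leave open whether 2,2-difluoro-1-hydroxyethyl in place of 2-hydroxyethyl changes this read-out at all.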